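Nitro for Hydrogen on a Diaryl Ether Thiosemicarbazone

A few compounds are considered here, and "the series" means these few. Any claim that something is new, unique, unknown or untested is made for them only; others in the source may bear on it.

Measured so far:
Compound 1, `Cc1ccc(Oc2ccc(/C=N/NC(=S)Nc3ccccc3)cc2)cc1`, gives 5.39.
Compound 2, `S=C(N/N=C/c1ccc(Oc2ccccc2)cc1)Nc1ccccc1`, gives 4.9.

Both compounds were measured in a physicochemical assay for lipophilicity, in phosphate buffer, measured as octanol-water partition, with a stated time of 24 h; on this read-out higher numbers stand for higher lipophilicity and lower numbers for lower lipophilicity. Compound 2 stands at the lower of the two numbers, with compound 1 above it; the step from methyl to hydrogen on an aromatic carbon gave a number 0.49 log units lower from compound 1 to compound 2 (beyond the scatter), a modest fall beyond the scatter.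

Compound 3, `O=[N+]([O-])c1ccc(Oc2ccc(/C=N/NC(=S)Nc3ccccc3)cc2)cc1`, is not yet measured. It differs from compound 2 by nitro in place of hydrogen on an aromatic carbon. Going by the values given here, the only step known here swaps a methyl for a hydrogen, so it touches a different kind of change and offers only a loose guide; no measured step puts a nitro in place of a hydrogen. On that thin basis the step from compound 2 to compound 3 is expected to be small, likely a slight fall, a number 0.20 log units lower from compound 2 to compound 3 (within the scatter), and possibly within the scatter. Compound 3 is therefore estimated at 4.7, between 4.3 and 5.2.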

Compound 3, partition coefficient: 4.95
Beside the measured number, compound 3's estimate is 0.25 log units below it, and the stated range covers the measured number.
By their numbers in this assay, from the lowest: compounds 2 and 3 (each within the scatter of the next); then compound 1.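

With nitro now at this position, para to a large group, this assay gives a number 0.05 log units higher from compound 2 to compound 3 (within the scatter), so the three heavy atoms of the nitro group leave the number no different from that with hydrogen. Set against methyl at the same carbon, nitro gives a number 0.44 log units lower from compound 1 to compound 3 (beyond the scatter), which means that among the three groups shown, methyl alone stands apart, while hydrogen and nitro cannot be told apart. No measurement shown here accounts for hydrogen and nitro reading alike.

From the compounds shown here alone, whether an amine, a methoxy group or a carboxylic acid at this carbon would read like hydrogen and nitro or like methyl remains open. Also open, going by these compounds, is whether nitro would read the same way on the other aromatic rings of the shared core.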